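Fluoro for methoxy on the benzyl ring of compound 1

The compounds below may be only part of what the source reports. "The series", "measured", "known", "first", "only" and "open" are said of these compounds alone.

Working notes on a small set of adenine-type compounds tested in a functional assay (spleen, spleen) for activation, with Mus musculus as the target; on this read-out higher numbers stand for an effect only at larger amounts of compound and lower numbers for an effect already at smaller amounts. Compound 1 `COc1ccc(Cn2c(O)nc3c(N)ncnc32)cc1` stands at the higher end of the two numbers obtained: in this assay compound 1 gives 10 uM. Among the compounds with values here, compound 2 `CCCCCOc1nc(N)c2nc(O)n(Cc3ccccc3)c2n1`, which carries a pentyloxy group on the core and an unsubstituted benzyl group, gives 0.01 uM in this assay, a much lower number, but the two structures differ in more than one place and no single step links them. Compound 3 `Nc1ncnc2c1nc(Cl)n2Cc1ccccc1` reaches only the limit of this assay, > 10 uM, and that value is a limit rather than a number (the limit of > 10 uM in this assay, at which 1 of the 3 values shown sits).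

Compound 4 `Nc1ncnc2c1nc(O)n2Cc1ccc(F)cc1` is not yet measured. It differs from compound 1 by fluoro in place of methoxy on an aromatic carbon. Within the data shown here, no measured pair shows this change on its own, so the expected step from compound 1 to compound 4 is set at no change at the digits printed from compound 1 to compound 4 (within the scatter), with no direction beyond the scatter. Compound 4 is therefore estimated at 10 uM in this assay, within the range 3 uM to 30 uM.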

Compound 4, minimum effective concentration: 10 uM
Beside the measured number, compound 4's estimate shows no gap at the digits printed; measured number inside the range.
By their numbers in this assay, from the lowest: compound 2; then compounds 1 and 4 (each within the scatter of the next).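

In this assay the series now has its first step at a single place: fluoro in place of methoxy on an aromatic carbon reads no change at the digits printed from compound 1 to compound 4 (within the scatter). Earlier compounds could not show this, as they differ from one another in more than one place. At this aromatic carbon, the read-out does not separate the two groups, even though fluoro brings fewer heavy atoms and no hydrogen-bond acceptor, and nothing shown offers a reason for this flat step.

Going by these compounds, whether an amine or a carboxylic acid on this aromatic carbon would move the number remains open. Also open, on these data alone, is whether the same exchange would read alike on a core bearing the pentyloxy group of compound 2.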